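Acetyl to Benzoyl on the Side Chain of Compound 2

This account rests on a few compounds, and the source may have more. Where it says the series, first, only, none or still open, it means among the compounds named here.

Measured so far:
compound 1, `O=C1c2ccccc2NS(=O)(=O)N1Cc1ccccc1`: > 200 ug/mL
compound 2, `CC(=O)OCCOCN1c2ccccc2C(=O)N(Cc2ccccc2)S1(=O)=O`: 103 ug/mL

In a functional assay on CCRF-CEM cells (Homo sapiens) for cytotoxicity (on this read-out higher numbers stand for lower toxicity in this test and lower numbers for higher toxicity in this test), compound 1 reaches only a limit of the assay, > 200 ug/mL. Compound 2, which carries a (2-acetoxyethoxy)methyl group on the sulfonamide nitrogen in the ring, gives 103 ug/mL. The step of an at least 1.9-fold lower number from compound 1 to compound 2 (0.28 log units; that floor lies within the scatter) rests on that limit, (the limit of > 200 ug/mL in this assay, at which 1 of the 2 values shown sits), so its true size is not known. Within the data shown here, compound 2 therefore holds the only real number in this assay; the other value is a limit.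

Compound 3, `O=C(OCCOCN1c2ccccc2C(=O)N(Cc2ccccc2)S1(=O)=O)c1ccccc1`, differs from compound 2 in one place: phenyl in place of methyl on a carbonyl carbon. Among the measured compounds shown here, no measured step touches this kind of change on a carbonyl carbon. For the measured compounds named here, the only step on record, an at least 1.9-fold lower number from compound 1 to compound 2 (0.28 log units; that floor lies within the scatter), concerns the arrival of the whole side chain, not the acyl group at its end, and its floor lies within the scatter. With nothing pointing in either direction, the estimated step of a 1.2-fold lower number from compound 2 to compound 3 (0.08 log units; within the scatter) from compound 2 is expected to stay within the scatter. Compound 3 is thus estimated at 85 ug/mL, between 35 ug/mL and 190 ug/mL.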

Compound 3, half-maximal cytotoxic concentration: 100 ug/mL
Beside the measured number, compound 3's estimate is 1.2-fold (0.07 log units) below it, within the range that was stated.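

In this assay, phenyl in place of methyl on a carbonyl carbon gives a 1.0-fold lower number from compound 2 to compound 3 (0.01 log units; within the scatter), so acetyl and benzoyl at the end of the side chain cannot be told apart on this read-out. Among these compounds, the earlier step spoke only to the arrival of the whole side chain, whereas this pair is the first with two real numbers, and it shows that this position takes a six-membered aromatic ring in place of methyl with no change beyond the scatter. Compound 1 remains a limit, so the effect of the side chain as a whole still has no known size: the limit of > 200 ug/mL in this assay, at which 1 of the 3 values shown sits.

From the compounds shown here alone, whether the same holds for other acyl groups, such as a longer chain in place of methyl or a benzoyl group carrying an amine or a carboxylic acid, stays open. Equally open, going by these compounds, is how a side chain ending in a free hydroxyl group, without any acyl group, would compare with compound 2 in this assay.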